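Swapping a carbamate for a nitrobenzamide in a sulfone hydroxamate

The source may hold more compounds than are shown below. What is called first, only, known or untested is meant among the compounds shown, and "the series" means these compounds.

Compound 1 `O=C(Nc1ccc(S(=O)(=O)C2CCC[C@@H]2C(=O)NO)cc1)OCc1ccccc1` carries a benzyloxy group on the carbonyl carbon of its amide. In an assay on isolated protein for inhibition of matrix metalloproteinase-9 (Homo sapiens), read by fluorescence, with stated times of 5 min and 30 min (on this read-out lower numbers stand for stronger inhibition and higher numbers for weaker inhibition), compound 1 gives 520 nM. Among the compounds with values here, this is the highest of the two numbers recorded, and the only other compound, compound 2 `O=C(NO)[C@H]1CCCC1S(=O)(=O)c1ccc(-c2ccc(Cl)c(Cl)c2)cc1`, reaches 0.76 nM in this assay. Compound 3 `O=C(Nc1ccc(S(=O)(=O)C2CCC[C@@H]2C(=O)NO)cc1)c1ccc([N+](=O)[O-])cc1` is a new analogue of compound 1 in which (4-nitrophenyl in place of benzyloxy on a carbonyl carbon). Within the data shown here, no measured pair shows this exact change, so the size of the step can only be guessed from the fact that the shared core is kept and only the group on the carbonyl carbon is exchanged. A modest shift toward a lower number, or none beyond the scatter, is expected in this assay, and the step from compound 1 to compound 3 is estimated at a 1.7-fold lower number from compound 1 to compound 3 (0.24 log units; within the scatter). For compound 3 the expected value in this assay is 300 nM, with a likely range from 60 nM to 1500 nM.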

Compound 3, half-maximal inhibitory concentration: 0.122 nM
Compound 3: middle estimate off by 2500-fold (3.39 log units), on the high side, and the stated range ends above it.
By their numbers in this assay, from the lowest: compound 3; then compound 2; then compound 1.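

In this assay, the group on the carbonyl carbon proves to be a place of very high sensitivity: 4-nitrophenyl in place of benzyloxy gives a 4300-fold lower number from compound 1 to compound 3 (3.63 log units; beyond the scatter), while the shared core stays the same. The exchange looks small when counted, as both groups hold one six-membered aromatic ring of carbon only and differ by a single heavy atom, so a small structural change here can go with a very large change in the number. Nothing measured here accounts for the size of this step.

From the compounds shown here alone, what a plain phenyl or a 4-aminophenyl group would give at this place stays open, so the step cannot yet be divided between the nitro group and the rest of the exchange. Going by these compounds, whether the same exchange would have a similar effect on another core is also open.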